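The source may report more compounds than this note shows. Statements on the series, on what has been measured and on what is new or still open speak of the compounds shown alone.

Series notes. Compound 1 `CCNC(=O)C1=C(C)NC(=O)NC1c1ccoc1`, compound 2 `CCNC(=O)C1=C(C)NC(=O)NC1c1cccs1` and compound 3 `CCC(CC)OC(=O)C1=C(C)NC(=O)NC1c1ccoc1` have been run in an assay on membranes from CHO cells for displacement of a labelled ligand from adenosine receptor A1 (Homo sapiens), read by scintillation counting, with a stated time of 60 min, tested at 1 uM; a lower number here means less inhibition, a higher number more inhibition at the concentration tested (going by the name of the read-out); compound 4 `CCC(CC)OC(=O)C1=C(C)NC(=O)NC1c1cccs1` has not. In this assay compound 1 gives 1%, compound 2 gives 1% and compound 3 gives 17%. The change thiophen-2-yl in place of furan-3-yl on a saturated ring carbon made no change at the digits printed from compound 1 to compound 2 (within the scatter). The two cores differ as (pentan-3-yl)oxy in place of ethylamino on a carbonyl carbon, which gave a number 16 percentage points higher from compound 1 to compound 3 (beyond the scatter). The change from compound 3 to compound 4 is thiophen-2-yl in place of furan-3-yl on a saturated ring carbon; it is the same kind of change as that from compound 1 to compound 2, though around the place the neighbouring ring atom bears a group of 8 heavy atoms rather than an ethylcarbamoyl group (5 heavy atoms). On the core of compound 3 a similarly flat step is expected, a number 2 percentage points lower from compound 3 to compound 4 (within the scatter), resting on no change at the digits printed from compound 1 to compound 2 (within the scatter) and on compound 3 standing at 17%. Compound 4 is therefore estimated at 15%, within 4% to 27%.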

Compound 4, a percentage reported as inhibition, at one concentration (the size of the read-out at that concentration, not a potency): 13%
Compound 4: middle estimate off by 2 percentage points, on the high side; low and high end bracket the measured number.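

In this assay, thiophen-2-yl in place of furan-3-yl gives a number 4 percentage points lower from compound 3 to compound 4 (within the scatter), and this step agrees with the one on the other core: the same change on two cores in this assay, no change at the digits printed (within the scatter) from compound 1 to compound 2 and a number 4 percentage points lower (within the scatter) from compound 3 to compound 4, 4 percentage points apart, within the scatter of two such steps. (Pentan-3-yl)oxy in place of ethylamino gives a number 12 percentage points higher from compound 2 to compound 4 (beyond the scatter), and this step also agrees with its earlier counterpart: the same change on two cores in this assay, a number 16 percentage points higher (beyond the scatter) from compound 1 to compound 3 and a number 12 percentage points higher (beyond the scatter) from compound 2 to compound 4, 4 percentage points apart, within the scatter of two such steps. Across these four compounds, each change therefore carries between the two cores, but this does not show that it would carry to other cores, and these read-outs at one concentration are not potencies.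

Open, from the compounds shown here alone, is whether either step would hold with a carboxylic acid or a longer alkyl chain on the carbonyl carbon. The same question stands for an amine on the saturated ring carbon.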